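Moving the Chlorine on the Benzyl Arm: Compound 4 Foreseen

The source may hold more compounds than are shown below. What is called first, only, known or untested is meant among the compounds shown, and "the series" means these compounds.

Measured in a functional assay on the whole organism (artery, strain albino) with Rattus norvegicus as the target, with a stated time of 60 min, at a dose of 10 mg/kg by the oral route; a higher number here means more inhibition at the dose given (going by the name of the read-out), a lower number less inhibition:
compound 1, `CC1=C(C(=O)Nc2ccc(F)cc2)C(c2ccc([N+](=O)[O-])cc2)N=C(SCc2ccccc2Cl)N1`, gives 6.2%
compound 2, `CC1=C(C(=O)Nc2ccc(F)cc2)C(c2ccc([N+](=O)[O-])cc2)N=C(SCc2cccc(Cl)c2)N1`, gives 7.2%
compound 3, `CC1=C(C(=O)Nc2ccc(Br)cc2)C(c2ccc(Cl)cc2Cl)N=C(SCc2ccccc2Cl)N1`, gives 11.8%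

The three numbers in this assay all lie within the usual scatter of one another, so none of them can be told apart with confidence. Compound 1 and compound 2 share one core and differ in a single place: 3-chlorophenyl in place of 2-chlorophenyl on a saturated chain carbon bound to a sulfur. That change gave a number 1 percentage points higher from compound 1 to compound 2 (within the scatter), a step too small to count as a real effect.

Compound 3 carries a different core, and the difference between the two cores is not broken down here. Compound 4, `CC1=C(C(=O)Nc2ccc(Br)cc2)C(c2ccc(Cl)cc2Cl)N=C(SCc2cccc(Cl)c2)N1`, has not yet been measured. It stands to compound 3 exactly as compound 2 stands to compound 1: 3-chlorophenyl in place of 2-chlorophenyl on a saturated chain carbon bound to a sulfur. The same change is made at the same place. For the measured compounds named here, the step seen between compound 1 and compound 2, namely a number 1 percentage points higher from compound 1 to compound 2 (within the scatter), is the only guide available.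

Compound 4 is therefore expected to give about 12.5% in this assay, with a likely range from 5% to 20%. The expected step is estimated as a number 0.7 percentage points higher from compound 3 to compound 4 (within the scatter), meaning essentially no change beyond the scatter.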

Compound 4, a percentage reported as inhibition, in the whole organism at one dose (the size of the read-out at that dose, not a potency): 6.2%
The estimate for compound 4 lay 6.3 percentage points above the measured number, within the range that was stated.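

In this assay, replacing 2-chlorobenzyl with 3-chlorobenzyl on the sulfur of the core of compound 3 gave a number 5.6 percentage points lower from compound 3 to compound 4 (within the scatter). Set beside the same change on the core of compound 1, this step gives no sign that the change behaves differently on the two cores: the same change on two cores in this assay, a number 1 percentage points higher (within the scatter) from compound 1 to compound 2 and a number 5.6 percentage points lower (within the scatter) from compound 3 to compound 4, 6.6 percentage points apart, within the scatter of two such steps This shows only that any difference between the cores is too small to detect here; it does not prove that the change carries over identically, and neither step shows that the change has a real effect on either core.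

The compounds shown leave open whether a different group on the sulfur, such as a benzyl carrying an amine or a carboxylic acid, or a longer carbon chain in place of the benzyl, would give a step beyond the scatter. With a single dose shown, they also leave open how these compounds would compare at other doses.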